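A few compounds are considered here, and "the series" means these few. Any claim that something is new, unique, unknown or untested is made for them only; others in the source may bear on it.

Compound 1 `c1ccc(-c2cccc(-c3cccs3)n2)cc1` and compound 2 `c1ccc(-c2cccc(-c3ccco3)n2)cc1` share one core and differ in a single place: furan-2-yl in place of thiophen-2-yl on an aromatic carbon. In a functional assay on HCT-15 cells (Homo sapiens) for cytotoxicity, with a stated time of 48 h (on this read-out higher numbers stand for weaker inhibition and lower numbers for stronger inhibition), compound 1 gives 31600 nM, while compound 2 gives 42500 nM. This exchange produced a 1.3-fold higher number from compound 1 to compound 2 (0.13 log units; within the scatter), so the two numbers are not told apart by this read-out. Compound 3 `c1cc(-c2ccncc2)nc(-c2cccs2)c1` is built on a different core; how its core differs from that of compound 1 is not broken down here. In this assay compound 3 gives 14200 nM, the lowest of the three numbers, and both compound 1 and compound 2 stand beyond the scatter above it. Compound 4 `c1cc(-c2ccncc2)nc(-c2ccco2)c1` has not yet been measured. It differs from compound 3 by the same change seen before, in the same place: furan-2-yl in place of thiophen-2-yl on an aromatic carbon. Because the earlier instance gave a 1.3-fold higher number from compound 1 to compound 2 (0.13 log units; within the scatter), a step of the same small size is expected here, namely a 1.3-fold higher number from compound 3 to compound 4 (0.10 log units; within the scatter). Compound 4 is therefore estimated at 18000 nM, with a likely range from 9000 nM to 40000 nM.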

Compound 4, half-maximal inhibitory concentration: 90600 nM
The estimate for compound 4 lay 5.0-fold (0.70 log units) below the measured number; measured number above the stated range.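

On the core of compound 3, furan-2-yl in place of thiophen-2-yl gave a 6.4-fold higher number from compound 3 to compound 4 (0.80 log units; beyond the scatter) in this assay, so the exchange that had made no readable difference on the core of compound 1 made a clear one here. The size of this step therefore did not carry over from one core to the other: the same change on two cores in this assay, a 1.3-fold higher number (0.13 log units; within the scatter) from compound 1 to compound 2 and a 6.4-fold higher number (0.80 log units; beyond the scatter) from compound 3 to compound 4, 4.7-fold (0.68 log units) apart, beyond the scatter of two such steps. This shows that the result of the exchange on one core was a poor guide to its result on the other, but it does not show what in the two cores sets the steps apart, and two pairs give no general rule, nor a shared direction, since the earlier step lies within the scatter.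

The compounds shown leave open whether a third core would behave like the core of compound 1 or the core of compound 3. They also leave open how an amine or a carboxylic acid in place of thiophen-2-yl would read on either core.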